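The compounds below may be only part of what the source reports. "The series", "measured", "known", "first", "only" and "open" are said of these compounds alone.

Working notes on the series

Growth inhibition is followed in a functional assay on A549 cells (Homo sapiens) for inhibition, read by sulforhodamine B assay, with a stated time of 72 h; on this read-out lower numbers stand for stronger inhibition of growth and higher numbers for weaker inhibition of growth. Compound 2, `O=C(/C=C/c1ccncc1-c1ccc2cc[nH]c2c1)N1CCOCC1`, carries a (morpholin-4-yl)carbonyl on an unsaturated linker. In this assay compound 2 reaches only the limit of the assay, > 10000 nM, and no number. Compound 1, `CNC(=O)/C=C/c1ccncc1-c1ccc2cc[nH]c2c1`, is its methylcarbamoyl counterpart, and in this assay compound 1 gives 7840 nM. The change, (methylamino in place of morpholin-4-yl on a carbonyl carbon), therefore makes an at least 1.2-fold lower number from compound 2 to compound 1 (0.10 log units; that floor lies within the scatter); the size of this step can only be stated as a floor because of the limit of > 10000 nM in this assay, at which 2 of the 3 values shown sit.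

Compound 3, `O=C(CCc1ccncc1-c1ccc2ccccc2c1)N1CCOCC1`, has a saturated linker and a different core; the difference between the core of compound 3 and that of compound 2 is not broken down here. In this assay compound 3 also sits at the limit of the assay, > 10000 nM, and gives no number.

Compound 4, `CNC(=O)CCc1ccncc1-c1ccc2ccccc2c1`, is not yet measured. It differs from compound 3 by methylamino in place of morpholin-4-yl on a carbonyl carbon. This is the same kind of change as from compound 2 to compound 1, but the place is not identical: in compound 2 the carbonyl carbon's other neighbour is a double-bonded chain carbon, whereas in compound 3 it is a saturated chain carbon. A step that the limit leaves unreadable from compound 3 to compound 4 is expected, resting on the floor seen in an at least 1.2-fold lower number from compound 2 to compound 1 (0.10 log units; that floor lies within the scatter) and on compound 3 standing at > 10000 nM. Compound 4 is thus estimated at 12000 nM in this assay, expected to fall between 5000 nM and 40000 nM.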

Compound 4, concentration for 50% growth inhibition: 10400 nM
For compound 4 the middle estimate is 1.2-fold (0.06 log units) above the measured one, within the range that was stated.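

The step from compound 3 to compound 4 cannot be read, and this result yields no new step, since compound 3 gives only a limit and no number: the limit of > 10000 nM in this assay, at which 2 of the 4 values shown sit.

The compounds shown leave open how large the change from morpholin-4-yl to methylamino is in this assay, on either the unsaturated or the saturated linker, and whether its size depends on the linker.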